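From Chloro to Bromo on an Antiproliferative Compound

The source may hold more compounds than are shown below. What is called first, only, known or untested is meant among the compounds shown, and "the series" means these compounds.

Among the compounds with values here, in a functional assay on MGC-803 cells (Homo sapiens) for antiproliferative activity, read by MTT assay, with a stated time of 72 h (a lower number here means a stronger inhibitor, a higher number a weaker inhibitor), compound 1 `O=C(COc1ccc(C(=O)/C=C/c2cccc(Cl)c2)cc1)N[C@H]1CCOC1=O` gives 29100 nM, the only exact number so far. Compound 2 `O=C1OCC[C@@H]1NC(=S)SCCOc1cccc2ccccc12` gives > 64000 nM, which is a limit of the assay and not a number. Compound 3 `O=C(COc1ccc(C(=O)/C=C/c2cccc(Br)c2)cc1)N[C@H]1CCOC1=O` differs from compound 1 by a single swap: bromo in place of chloro on an aromatic carbon. Within the data shown here, no measured pair shows this change, so the expectation rests on compound 1 at 29100 nM alone, with no step beyond the scatter foreseen in this assay. The expected step is a 1.1-fold lower number from compound 1 to compound 3 (0.03 log units; within the scatter). Compound 3 is estimated at 27000 nM, within an expected range of 12000 nM to 60000 nM.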

Compound 3, half-maximal inhibitory concentration: 11900 nM
Estimate against measurement, compound 3: 2.3-fold (0.36 log units) above; measured number outside the range, below it.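

In this assay, going from 3-chlorophenyl to 3-bromophenyl gives a 2.4-fold lower number from compound 1 to compound 3 (0.39 log units; beyond the scatter). This shows that the number responds to the exchange of one halogen for another at this place on the ring, something compound 1 alone could not show. Nothing measured here explains the modest gain. On these data alone, it remains open whether an iodo, a methoxy or an amine at the same place would lower the number further or raise it again, and whether bromo has a similar effect elsewhere on this ring.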